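Swapping a Urea Ring's Chloro Pattern on Two Cores

A few compounds are considered here, and "the series" means these few. Any claim that something is new, unique, unknown or untested is made for them only; others in the source may bear on it.

The measured compounds are:
- compound 1, `COc1cccc(Nc2ccnc(N3CCN(C(=O)Nc4ccccc4Cl)CC3)n2)c1`, giving 5260 nM
- compound 2, `COc1cccc(Nc2ccnc(N3CCN(C(=O)Nc4ccc(Cl)cc4Cl)CC3)n2)c1`, giving 11300 nM
- compound 3, `COc1cccc(Nc2cc(N3CCN(C(=O)Nc4ccccc4Cl)CC3)ncn2)c1`, giving 2800 nM

These three were tested in a functional assay on MDA-MB-231 cells (Homo sapiens) for antiproliferative activity, read by MTT assay, with a stated time of 24 h; on this read-out lower numbers stand for stronger inhibition and higher numbers for weaker inhibition. Compound 1 and compound 2 share one core and differ only at the aryl urea end: chloro in place of hydrogen on an aromatic carbon. That change made a step of a 2.1-fold higher number from compound 1 to compound 2 (0.33 log units; beyond the scatter), so compound 2 inhibited cell growth less strongly than compound 1.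

Compound 3 carries the same aryl urea as compound 1 on a core built from the same atoms joined differently; how the two cores differ is not broken down here. Its value sits within the scatter of that of compound 1, so the two cannot be ranked against each other, while compound 3 and compound 2 lie beyond the scatter.

Compound 4, `COc1cccc(Nc2cc(N3CCN(C(=O)Nc4ccc(Cl)cc4Cl)CC3)ncn2)c1`, has not been measured. It relates to compound 3 exactly as compound 2 relates to compound 1: chloro in place of hydrogen on an aromatic carbon, in the same place on the same ring. Because the earlier step was a 2.1-fold higher number from compound 1 to compound 2 (0.33 log units; beyond the scatter), a step of similar size, a 2.1-fold higher number from compound 3 to compound 4 (0.32 log units; beyond the scatter), is expected in this assay. The expectation for compound 4 is therefore 5900 nM, with a likely range from 2500 nM to 14000 nM.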

Compound 4, half-maximal inhibitory concentration: 7230 nM
Estimate against measurement, compound 4: 1.2-fold (0.09 log units) below; the range from low to high includes it.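

In this assay, going from 2-chlorophenyl to 2,4-dichlorophenyl on the core of compound 3 gave a 2.6-fold higher number from compound 3 to compound 4 (0.41 log units; beyond the scatter) and so left compound 4 inhibiting cell growth less strongly than compound 3. The same change on the two cores moved the number in the same direction and by steps that cannot be told apart: the same change on two cores in this assay, a 2.1-fold higher number (0.33 log units; beyond the scatter) from compound 1 to compound 2 and a 2.6-fold higher number (0.41 log units; beyond the scatter) from compound 3 to compound 4, 1.2-fold (0.08 log units) apart, within the scatter of two such steps. For this one pair of cores, then, the step measured on one core carried over to the other, but two pairs show nothing about why the added chloro weakens inhibition, nor whether the step would stay the same on any further core.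

On these data alone, it remains open whether a different group in the same place on the urea ring, such as a fluoro, a methyl or an amine, would shift the number in the same way on both cores. As far as these compounds go, it is also open whether the two cores would still respond alike if the methoxy group on the other aromatic ring gave way to something else, such as a hydroxyl or a longer chain like an ethoxy.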